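This account rests on a few compounds, and the source may have more. Where it says the series, first, only, none or still open, it means among the compounds named here.

In a functional assay on the whole organism (Myocardium) with Canis familiaris (Canis lupus familiaris) as the target, at a dose of 1.875 mg/kg by the intravenous route (a lower number here means that less compound is needed, a higher number that more compound is needed for the effect), three compounds have been tested so far. Compound 1 `Cc1nc(O)nc2ccc(N3CCN(C)CC3)cc12` returned only a limit, > 1.87 mg/kg. Compound 2 `COc1cc2c(C)nc(O)nc2c(OC)c1OC` also returned only a limit, > 1.87 mg/kg. For the measured compounds named here, compound 3 `COc1ccc2nc(O)ncc2c1OC` gives 1.64 mg/kg, the only actual number among the three, so it is the sole numerical reference point for the series.

Compound 4 `CCc1nc(O)nc2ccc(OC)c(OC)c12` has not yet been measured. It differs from compound 3 by ethyl in place of hydrogen on an aromatic carbon, next to the ring nitrogen. Going by the values given here, no measured pair isolates a change of this kind, so the expectation rests on compound 3 at 1.64 mg/kg and on the structural change alone. No step beyond the scatter is expected in this assay, with only a slight lean towards less compound being needed. The expected change is a 1.4-fold lower number from compound 3 to compound 4 (0.14 log units; within the scatter). A result reported only as a limit would also not be surprising. For compound 4 the estimated value is 1.2 mg/kg, with an expected range from 0.4 mg/kg to 2.6 mg/kg.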

Compound 4, dose for half-maximal effect: 0.51 mg/kg
The estimate for compound 4 lay 2.4-fold (0.37 log units) above the measured number, and the stated range covers the measured number.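

In this assay, for the compounds shown here, ethyl in place of hydrogen on an aromatic carbon, next to the ring nitrogen, gives a 3.2-fold lower number from compound 3 to compound 4 (0.51 log units; beyond the scatter), the first step that can be read at all. It shows that this carbon need not carry hydrogen for the effect to appear, and that an ethyl group here goes with less compound being needed, by more than the usual scatter. Compounds 1 and 2 cannot add a second step, because they return no number: the limit of > 1.87 mg/kg in this assay, at which 2 of the 4 values shown sit.

From the compounds shown here alone, whether a longer chain such as propyl, or an amine or a carboxylic acid, at this same carbon would move the number further, not at all or the other way remains open. So does whether the ethyl step holds on a core with other substituents, since this single pair speaks only for the core of compound 3.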